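Urea to amide on the shared core

A few compounds are considered here, and "the series" means these few. Any claim that something is new, unique, unknown or untested is made for them only; others in the source may bear on it.

Compound 2 `COc1cc(Cl)cc(-c2nn(-c3cccc(NC(=O)Nc4ccc(Cl)c(C(F)(F)F)c4)c3)cc2-c2ccncc2)c1` gives -88% in a functional assay on SK-MEL-28 cells (Homo sapiens) for inhibition, read by sulforhodamine B assay, with a stated time of 48 h, tested at 100 uM (a higher number here means a weaker effect of the compound at the concentration tested, a lower number a stronger effect), the second highest of three numbers; compound 1 `O=C(Nc1cccc(-n2cc(-c3ccncc3)c(-c3cc(O)cc(Cl)c3)n2)c1)Nc1ccc(Cl)c(C(F)(F)F)c1` gives -89% and the step of a number 1 percentage points higher from compound 1 to compound 2 (within the scatter) lies within the scatter, while compound 3 `COc1cc(Cl)cc(-c2nn(-c3cccc(NC(=O)Nc4cc(C(F)(F)F)cc(C(F)(F)F)c4)c3)cc2-c2ccncc2)c1` gives -58%, a higher number that lies beyond it. Compound 4 `COc1cc(Cl)cc(-c2nn(-c3cccc(NC(=O)c4cccc(C(F)(F)F)c4)c3)cc2-c2ccncc2)c1` differs from compound 2 by 3-(trifluoromethyl)phenyl in place of (4-chloro-3-(trifluoromethyl)phenyl)amino on a carbonyl carbon. Among the measured compounds shown here, no measured step touches this change; the only step known is the methyl on oxygen, and compound 3 shows only that another aryl group on the urea shifts the number upward. The expectation for compound 4 is therefore uncertain, with an expected step of a number 33 percentage points higher from compound 2 to compound 4 (beyond the scatter) toward a weaker effect. Compound 4 is estimated at -55%, within -95% to 0%.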

Compound 4, a percentage reported as activity, at one concentration (the size of the read-out at that concentration, not a potency): 75%
Beside the measured number, compound 4's estimate is 130 percentage points below it, outside the stated range (above it).
By their numbers in this assay, from the lowest: compounds 1 and 2 (each within the scatter of the next); then compound 3; then compound 4.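

The carbonyl carbon is highly sensitive to this change: 3-(trifluoromethyl)phenyl in place of (4-chloro-3-(trifluoromethyl)phenyl)amino gives a number 163 percentage points higher from compound 2 to compound 4 (beyond the scatter) in this assay. The change removes the amino nitrogen, with its hydrogen-bond donor, and the chlorine together, so the step cannot be assigned to either one alone. Nothing available explains the size of this step.

Still open, going by these compounds, is whether (3-(trifluoromethyl)phenyl)amino on the carbonyl carbon would read closer to compound 2 or to compound 4. A benzyl group at the same place would test whether an atom between carbonyl and aryl ring is enough.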